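Swapping the benzyl group of compound 2

The source may hold more compounds than are shown below. What is called first, only, known or untested is meant among the compounds shown, and "the series" means these compounds.

compound 1 `CCC(=O)N(c1ccc(Cl)c(Cl)c1)C1CCCC1O`: 20 mg/kg
compound 2 `CCC(=O)N(c1ccc(Cl)c(Cl)c1)C1CCCC1N(C)Cc1ccccc1`: > 50 mg/kg

In a functional assay on the whole organism for positive allosteric modulation, with Mus musculus as the target (on this read-out lower numbers stand for an effect already at smaller amounts and higher numbers for an effect only at larger amounts of compound), compound 2 gives > 50 mg/kg, which is a limit and not a number. Going by the values given here, the one measured step, an at least 2.5-fold higher number from compound 1 to compound 2 (0.39 log units; beyond the scatter), put benzyl(methyl)amino in place of hydroxy on a saturated ring carbon. Compound 3 `CCC(=O)N(c1ccc(Cl)c(Cl)c1)C1CCCC1N(C)CCN(C)C` keeps that position but changes the amine: (dimethylamino)methyl in place of phenyl on a saturated chain carbon bound to an amine nitrogen. That step bears only loosely, as it did not touch this phenyl, so no change beyond the scatter is expected, and another limit is quite possible. The expected change is a number no higher from compound 2 to compound 3 (the limit leaves the size open). For compound 3 the estimate is 50 mg/kg, with an expected range from 20 mg/kg to 120 mg/kg.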

Compound 3, dose for half-maximal effect: 20 mg/kg
Compound 3: middle estimate off by 2.5-fold (0.40 log units), on the high side, within the range that was stated.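

In this assay there is an at least 2.5-fold lower number from compound 2 to compound 3 (0.39 log units; beyond the scatter), so the change from phenyl to (dimethylamino)methyl on the chain matters at this position. There is also no change at the digits printed from compound 1 to compound 3 (within the scatter), so (2-(dimethylamino)ethyl)(methyl)amino on the saturated ring carbon matches hydroxy there. An amine on this ring carbon therefore does not by itself raise the number, since compound 3 carries one as well as compound 2.

Going by these compounds, compound 2 stands at a limit, so the full size of its steps stays open: the limit of > 50 mg/kg in this assay, at which 1 of the 3 values shown sits. Whether a longer chain or a morpholine ring at the chain end would keep this value also remains open.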